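A few compounds are considered here, and "the series" means these few. Any claim that something is new, unique, unknown or untested is made for them only; others in the source may bear on it.

Measured compounds in an assay on cells with melanin-concentrating hormone receptor 1 (Homo sapiens) as the target, read by radioligand binding; a higher number here means a weaker inhibitor, a lower number a stronger inhibitor:
- compound 1 `Nc1ccc2cccc(OC3CCCCC3)c2n1` gives 361 nM
- compound 2 `COCC(C)Oc1cccc2ccc(N)nc12` gives 606 nM
- compound 3 `Nc1ccc2cccc(OCCC3CCCCC3)c2n1` gives 808 nM

Compound 3 carries the highest of the three numbers in this assay. Against compound 2 the gap is within the scatter, so the two cannot be ordered; against compound 1 the gap is beyond the scatter, and compound 1 is the stronger of that pair.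

Compound 4 `Nc1ccc2cccc(OCCC(F)(F)F)c2n1` is not yet measured. It differs from compound 3 in one place: trifluoromethyl in place of cyclohexyl on a saturated chain carbon, two bonds along the chain from an oxygen on an aromatic ring. For the measured compounds named here, the only measured step that touches the same region of the molecule is the exchange of the group on the aromatic oxygen, a 1.7-fold higher number from compound 1 to compound 2 (0.22 log units; within the scatter), which stayed within the scatter. A single step, and one of a different kind (a group directly on the oxygen rather than two bonds along the chain), gives weak footing. On that footing, no step beyond the scatter in this assay is expected from compound 3 to compound 4, in either direction, with the range left wide.

The estimate for compound 4 in this assay is 900 nM, with a likely span from 350 nM to 2500 nM. This corresponds to an expected step of a 1.1-fold higher number from compound 3 to compound 4 (0.05 log units; within the scatter).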

Compound 4, half-maximal inhibitory concentration: 722 nM
Estimate against measurement, compound 4: 1.2-fold (0.10 log units) above, and the stated range covers the measured number.
By their numbers in this assay, from the lowest: compounds 1, 2, 4 and 3 (each within the scatter of the next, the first and the last beyond it).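

In this assay, trifluoromethyl in place of cyclohexyl on a saturated chain carbon, two bonds along the chain from an oxygen on an aromatic ring, gives a 1.1-fold lower number from compound 3 to compound 4 (0.05 log units; within the scatter) and so leaves no readable difference at this place. A group of four heavy atoms with no ring thus reads the same here as a six-membered non-aromatic ring of carbon only. Taken as a whole group on the oxygen, 3,3,3-trifluoropropyl also stays within the scatter of the other two groups, with a 1.2-fold higher number from compound 2 to compound 4 (0.08 log units; within the scatter) against 1-(methoxymethyl)ethyl and a 2.0-fold higher number from compound 1 to compound 4 (0.30 log units; within the scatter) against cyclohexyl.

Going by these compounds, whether an amine or a carboxylic acid in place of trifluoromethyl, or a longer chain on the oxygen, would give a step beyond the scatter remains open. Nothing at hand accounts for these groups reading alike.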